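Methoxy for isopropyl: the next step in the series

The source may report more compounds than this note shows. Statements on the series, on what has been measured and on what is new or still open speak of the compounds shown alone.

In a functional assay on NZB5 cells (Homo sapiens) for inhibition, read by thymidine incorporation, with a stated time of 5 days (on this read-out higher numbers stand for weaker inhibition and lower numbers for stronger inhibition), compound 1 (`CN(/N=C/c1cnn2ccc(C#N)cc12)S(=O)(=O)c1cc([N+](=O)[O-])ccc1F`) gives 480 nM and compound 2 (`CC(C)c1ccc([N+](=O)[O-])cc1S(=O)(=O)N(C)/N=C/c1cnn2ccc(C#N)cc12`) gives 180 nM as the lower of the two numbers. Compound 3 (`COc1ccc([N+](=O)[O-])cc1S(=O)(=O)N(C)/N=C/c1cnn2ccc(C#N)cc12`) carries methoxy in place of isopropyl on an aromatic carbon. Within the data shown here, the only measured step at this carbon is modest and beyond the scatter (a 2.7-fold lower number from compound 1 to compound 2 (0.43 log units; beyond the scatter)), with isopropyl in place of fluoro. Among the measured compounds shown here, no methoxy analogue has been measured, so this single step is the only guide. Only a small rise is expected in this assay (a 1.7-fold higher number from compound 2 to compound 3 (0.22 log units; within the scatter)). Compound 3 is estimated near 300 nM (range 120 nM to 750 nM).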

Compound 3, half-maximal inhibitory concentration: 90 nM
Compound 3: the middle estimate sits 3.3-fold (0.52 log units) above what was measured, outside the stated range (below it).
By their numbers in this assay, from the lowest: compounds 3 and 2 (each within the scatter of the next); then compound 1.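

At this carbon, methoxy and isopropyl are not separated, with a 2.0-fold lower number from compound 2 to compound 3 (0.30 log units; within the scatter), so a carbon-only branched group and an oxygen-linked group read alike here. Methoxy in place of fluoro gives a 5.3-fold lower number from compound 1 to compound 3 (0.73 log units; beyond the scatter), so the step away from fluoro is not confined to isopropyl, and fluoro is the group that stands apart among the three. Nothing available bears on what lies behind these steps. Going by these compounds, how an amine or a longer chain at this carbon would read remains open.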